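Thioether chain extension in a bicyclic enone series

This account rests on a few compounds, and the source may have more. Where it says the series, first, only, none or still open, it means among the compounds named here.

Compound 1 `O=C1C(Br)=C[C@H]2CO[C@@H]1O2`: 14000 nM
Compound 2 `CCCCS[C@H]1CC(=O)[C@@H]2OC[C@H]1O2`: "not active" (no number reported)
Compound 3 `CCCCCCS[C@H]1CC(=O)[C@@H]2OC[C@H]1O2`: not yet measured

In a functional assay on HepG2 cells (Homo sapiens) for cytotoxicity, read by MTT assay, with a stated time of 48 h (a higher number here means a weaker inhibitor, a lower number a stronger inhibitor), compound 1 gives 14000 nM, whereas compound 2 is recorded as "not active" (no number reported) and carries no number. Compound 2 therefore cannot be placed on a numerical scale; it stands only as the member of the pair without a measurable read-out. Compound 3 differs from compound 2 by ethyl in place of hydrogen on a saturated chain carbon, four bonds along the chain from a sulfur. Going by the values given here, no measured step covers this change, so the expectation rests on compound 2 alone: a chain extension on a compound that gave no number is expected to yield no step beyond the usual scatter, with a high chance that compound 3 again returns no number. For compound 3 in this assay the half-maximal inhibitory concentration is estimated at 60000 nM, within a range from 15000 nM to 250000 nM.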

Compound 3, half-maximal inhibitory concentration: "not active" (no number reported)
For compound 3 the study gives words and no number, and the estimate cannot be compared.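

Compound 2 and compound 3 both carry words and no number, so no step can be read between them. The compounds shown leave open whether in this assay any thioether chain length gives a number. No supporting evidence bears on this result.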